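The compounds below may be only part of what the source reports. "The series", "measured", "known", "first", "only" and "open" are said of these compounds alone.

Compound 2 `CC1(C)C=C(n2ccccc2=O)c2cc(C=O)ccc2O1` carries a formyl group on the aromatic ring of its core. In a functional assay (aorta) with Rattus norvegicus as the target (a higher number here means a more potent compound, by a factor of ten per unit of this negative logarithm, a lower number a less potent compound), compound 2 gives 6.91. Within the data shown here, its one measured neighbour is compound 1 `CCC(=O)c1ccc2c(c1)C(n1ccccc1=O)=CC(C)(C)O2`, with ethyl where compound 2 has hydrogen on the carbonyl carbon; in this assay compound 1 gives 6.63. The step of a number 0.28 log units higher from compound 1 to compound 2 (within the scatter) leaves the two numbers within the scatter of each other, so neither compound can be called the more potent.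

Compound 3 `CC1(C)C=C(n2ccccc2=O)c2cc(C#N)ccc2O1` is not yet measured. It differs from compound 2 in one place: cyano in place of formyl on an aromatic carbon. Among the measured compounds shown here, no measured step exchanges one group for another at this aromatic carbon, so nothing seen so far bears directly on it; the single step available, from compound 1 to compound 2, altered the same carbonyl group and stayed within the scatter. The number for compound 3 is therefore expected to stay close to that of compound 2, with an expected step of a number 0.01 log units lower from compound 2 to compound 3 (within the scatter) that is no larger than the scatter. In this assay compound 3 is estimated at 6.9, within a range from 6.3 to 7.5.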

Compound 3, logarithm of the reciprocal of the active concentration, log(1/C): 7.67
For compound 3 the middle estimate is 0.77 log units below the measured one; the whole stated range lies below it.
By their numbers in this assay, from the lowest: compounds 1 and 2 (each within the scatter of the next); then compound 3.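

In this assay, cyano in place of formyl on this aromatic carbon gives a number 0.76 log units higher from compound 2 to compound 3 (beyond the scatter), and cyano in place of propanoyl gives a number 1.04 log units higher from compound 1 to compound 3 (beyond the scatter). The earlier step changed only what sat on the carbonyl carbon and stayed within the scatter, whereas replacing the whole carbonyl group with a nitrile moves the number beyond it, so this position does respond to the group it carries. Nothing available here explains why the number rises.

Among these compounds, with only three groups compared at this carbon, it remains open whether the nitrile is unusual or whether an amine, a carboxylic acid or a nitro group would match or pass it. From the compounds shown here alone, it is also open whether the same exchange would give a similar rise on a different core.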